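Methyl on the benzimidazole ring: an expected step

This account rests on a few compounds, and the source may have more. Where it says the series, first, only, none or still open, it means among the compounds named here.

Measured so far in a functional assay on Venous blood for antagonist activity at C-X-C chemokine receptor type 3 (Homo sapiens), read by flow cytometry, with a stated time of 30 min, in the presence of a further agent that is not named here; on this read-out higher numbers stand for weaker inhibition and lower numbers for stronger inhibition:
- compound 1, `Cc1nc(C)n(CC(=O)N2CCN(c3sc(C(F)(F)F)nc3-c3nc4c(F)cccc4[nH]3)C[C@H]2C)n1`, gives 321 nM
- compound 2, `Cc1nc(C)n(CC(=O)N2CCN(c3sc(C(F)(F)F)nc3-c3nc4ccccc4[nH]3)C[C@H]2C)n1`, gives 237 nM

Compound 2 has the lower of the two numbers recorded so far, but the gap to compound 1, a 1.4-fold lower number from compound 1 to compound 2 (0.13 log units; within the scatter), is within the scatter, so the two compounds cannot be told apart on potency.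

Compound 3, `Cc1nc(C)n(CC(=O)N2CCN(c3sc(C(F)(F)F)nc3-c3nc4cccc(C)c4[nH]3)C[C@H]2C)n1`, is not yet measured. It differs from compound 2 in one place: methyl in place of hydrogen on an aromatic carbon.

For the measured compounds named here, only one measured step touches this position. Replacing fluoro with hydrogen there gave a 1.4-fold lower number from compound 1 to compound 2 (0.13 log units; within the scatter), a change within the scatter. That suggests the position tolerates a small substituent without a large shift, though a methyl group is a different substituent from fluoro and nothing measured shows how the methyl itself behaves. On this basis compound 3 is expected to give a number close to that of compound 2, with a step of about a 1.3-fold higher number from compound 2 to compound 3 (0.10 log units; within the scatter), not clearly beyond the scatter in either direction. The estimate for compound 3 is 300 nM, with a range from 120 nM to 750 nM.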

Compound 3, half-maximal inhibitory concentration: 376 nM
The estimate for compound 3 lay 1.3-fold (0.10 log units) below the measured number; low and high end bracket the measured number.
By their numbers in this assay, from the lowest: compounds 2, 1 and 3 (each within the scatter of the next).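

In this assay, putting a methyl group on this aromatic carbon gives a 1.6-fold higher number from compound 2 to compound 3 (0.20 log units; within the scatter), so this first carbon substituent at the position produces no shift that can be separated from ordinary assay variation. Comparing the 7-methyl-1H-benzimidazol-2-yl group with the fluoro-bearing group of compound 1 gives a 1.2-fold higher number from compound 1 to compound 3 (0.07 log units; within the scatter), which means that hydrogen, fluoro and methyl cannot be told apart here on potency, and the tolerance seen earlier for a small atom now extends to a small carbon group. No supporting measurement is available to explain this flat result.

What the three compounds leave open is how much larger or different a group this aromatic carbon can carry, for example an ethyl group, a methoxy group, an amine or a carboxylic acid. They also do not show whether a methyl group on another carbon of the same six-membered aromatic ring would behave in the same way.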